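Swapping 4-bromophenyl for 2-fluorophenyl on compound 1

The source may report more compounds than this note shows. Statements on the series, on what has been measured and on what is new or still open speak of the compounds shown alone.

- Compound 1 `C[C@H](NC(=O)/C(C#N)=C/c1cccc(Br)n1)c1ccc(Br)cc1`: 2000 nM
- Compound 2 `C[C@H](NC(=O)/C(C#N)=C/c1cccc(Br)n1)c1cc(C(F)(F)F)cc(C(F)(F)F)c1`: "not determined" (no result reported)
- Compound 3 `COC(=O)C[C@H](NC(=O)/C(C#N)=C/c1cccc(Br)n1)c1ccccc1`: "not determined" (no result reported)

In a functional assay on OCI-My4 cells (Homo sapiens) for antiproliferative activity, read by MTT assay, with a stated time of 72 h (a lower number here means a stronger inhibitor, a higher number a weaker inhibitor), compound 1 gives 2000 nM. Among the measured compounds shown here, that is the only number in this small set, since no result was reported for compound 2 or compound 3. Compound 1 therefore cannot be ranked against anything, and its value serves only as a single reference point.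

The next compound to be tested is compound 4 `C[C@H](NC(=O)/C(C#N)=C/c1cccc(Br)n1)c1ccccc1F`, which keeps the core of compound 1 and changes one group. The change is 2-fluorophenyl in place of 4-bromophenyl on a saturated chain carbon bound to an amide-type nitrogen and a saturated chain carbon. In words, 2-fluorophenyl takes the place of 4-bromophenyl on a saturated chain carbon bound to an amide-type nitrogen and a saturated chain carbon.

For the measured compounds named here, the set holds no step between measured compounds, so nothing shows how this assay responds to a change at this place. Going by the values given here, the only anchor is compound 1 at 2000 nM, and the expectation stays close to it, with no shift beyond the scatter in either direction. The expected change is a 1.3-fold higher number from compound 1 to compound 4 (0.10 log units; within the scatter). The range is kept wide, since a single value supports the estimate. For compound 4 the estimated value is 2500 nM, expected to lie between 800 nM and 8000 nM.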

Compound 4, half-maximal inhibitory concentration: 2400 nM
For compound 4 the middle estimate is 1.0-fold (0.02 log units) above the measured one; low and high end bracket the measured number.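

In this assay, among the compounds shown here, putting 2-fluorophenyl in place of 4-bromophenyl on the saturated chain carbon gives a 1.2-fold higher number from compound 1 to compound 4 (0.08 log units; within the scatter), the first step that can be read at this place, and it leaves compound 1 and compound 4 indistinguishable. Both groups count the same heavy atoms and the same single six-membered aromatic ring, and they differ in which halogen they carry and where it stands, so this one step shows that this particular exchange leaves the read-out within the scatter but cannot separate the two differences. No measurement of any other property accompanies the result, so the finding remains a description of the numbers alone.

Steps involving compound 2 and compound 3 cannot be read, so the set offers no second comparison at this place. Going by these compounds, it remains open whether a group of a very different kind here, such as a longer chain or a phenyl ring carrying an amine or a carboxylic acid, would also stay within the scatter of compound 1.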